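Trading a Phenyl for an Ethyl on the Alkyne Chain

The source may report more compounds than this note shows. Statements on the series, on what has been measured and on what is new or still open speak of the compounds shown alone.

In a functional assay on MIA PaCa-2 cells (Homo sapiens) for antiproliferative activity, read by MTT assay, with a stated time of 3 days (on this read-out higher numbers stand for weaker inhibition and lower numbers for stronger inhibition), compound 2 `O=C1c2ccccc2C(=O)N1C/C=C/Cn1cc(C#CCCc2ccccc2)c(=O)[nH]c1=O` gives 27000 nM, the only actual number among the two results shown. Compound 1 `CCCCC#Cc1cn(C/C=C\CN2C(=O)c3ccccc3C2=O)c(=O)[nH]c1=O` reaches only an assay limit, > 100000 nM; this is the limit of > 100000 nM in this assay, at which 1 of the 2 values shown sits. Compound 3 `CCCCC#Cc1cn(C/C=C/CN2C(=O)c3ccccc3C2=O)c(=O)[nH]c1=O` has not been measured. It differs from compound 2 by ethyl in place of phenyl on a saturated chain carbon, two bonds along the chain from a triple-bonded carbon. Among the measured compounds shown here, no measured pair shares exactly this change, so the size of the move in this assay can only be estimated; a shift toward weaker inhibition, somewhat beyond the usual scatter, is expected. Compound 3 is therefore expected to give 60000 nM, between 20000 nM and 200000 nM, which amounts to a 2.2-fold higher number from compound 2 to compound 3 (0.35 log units; beyond the scatter).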

Compound 3, half-maximal inhibitory concentration: 77000 nM
Beside the measured number, compound 3's estimate is 1.3-fold (0.11 log units) below it; measured number inside the range.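

Trading phenyl for ethyl at this place gives a 2.9-fold higher number from compound 2 to compound 3 (0.46 log units; beyond the scatter) in this assay, so the end of the alkyne chain does affect the read-out, though only modestly. Changing the double bond from Z to E gives an at least 1.2-fold lower number from compound 1 to compound 3 (0.11 log units; that floor lies within the scatter). Compound 1 stands at an assay limit, so the size of this change cannot be read: the limit of > 100000 nM in this assay, at which 1 of the 3 values shown sits.

Still open, as far as these compounds go, is whether the aromatic ring itself or simply a larger group matters here. A longer chain, or an amine or carboxylic acid at the chain end, could help separate the two.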